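The source may hold more compounds than are shown below. What is called first, only, known or untested is meant among the compounds shown, and "the series" means these compounds.

Measured compounds:
Compound 1 `CCNCc1cc(C)cc(Nc2nc3ccccc3n2Cc2ccc(C(F)(F)F)cc2)c1O` gives 51% in an ADME assay on microsomes from liver (Rattus norvegicus) for metabolic stability, read by LC-MS, with a stated time of 30 min, tested at 1 uM; a lower number here means that less of the compound is left, a higher number that more of the compound is left.
Compound 2 `CCNCc1cc(Cl)cc(Nc2nc3ccccc3n2Cc2ccc(C(F)(F)F)cc2)c1O` gives 66% in this assay.
Compound 3 `CCNCc1cc(Cl)cc(Nc2nc3cc(F)c(F)cc3n2Cc2ccc(C(F)(F)F)cc2)c1O` gives 98% in this assay.

Compound 3 stands highest of the three in this assay, beyond the scatter against both compound 2 and compound 1. How the core of compound 3 differs from the core of compound 2 is not broken down here. One change occurs twice in the set: methyl in place of chloro on an aromatic carbon, which produced a number 15 percentage points lower from compound 2 to compound 1 (beyond the scatter). Compound 4 `CCNCc1cc(C)cc(Nc2nc3cc(F)c(F)cc3n2Cc2ccc(C(F)(F)F)cc2)c1O` is not yet measured; against compound 3 it carries the same kind of change, (methyl in place of chloro on an aromatic carbon), with the place described in the same words. Within the data shown here, the step expected in this assay is a number 14 percentage points lower from compound 3 to compound 4 (beyond the scatter), resting on a number 15 percentage points lower from compound 2 to compound 1 (beyond the scatter) as the only earlier instance of the change. Compound 4 is therefore expected near 84%, estimated to fall between 68% and 98%.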

Compound 4, percent of the compound remaining: 77%
Compound 4: the middle estimate sits 7 percentage points above what was measured; measured number inside the range.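

Methyl in place of chloro on an aromatic carbon gives the same direction of step on the second core in this assay, with a number 21 percentage points lower from compound 3 to compound 4 (beyond the scatter). Set beside the earlier step, the two agree: the same change on two cores in this assay, a number 15 percentage points lower (beyond the scatter) from compound 2 to compound 1 and a number 21 percentage points lower (beyond the scatter) from compound 3 to compound 4, 6 percentage points apart, within the scatter of two such steps. In this series the change thus carried over between the core of compound 2 and the core of compound 3 with a similar size of step, but two pairs do not show that it would hold on other cores, nor do they show why the number falls.

Open, from the compounds shown here alone, is whether bromo or a nitrile at this place would follow chloro or methyl. Also open, going by these compounds, is how the step behaves when a longer amine chain stands in place of the (ethylamino)methyl group.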